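Trading methoxy for trifluoromethyl in a cytotoxicity pair

This account rests on a few compounds, and the source may have more. Where it says the series, first, only, none or still open, it means among the compounds named here.

Measured so far in a functional assay on V79 cells (Cricetulus griseus) for cytotoxicity, read by colony formation; a lower number here means a stronger inhibitor, a higher number a weaker inhibitor:
Compound 1 `COc1c(N2CCC(C)(N)C2)c(F)cc2c(=O)c(C(=O)O)cn(C3CC3)c12`: 38 ug/mL
Compound 2 `COc1c(N2CCC(C)(N)C2)c(F)cc2c(=O)c(C(=O)O)cn(-c3ccc(F)cc3F)c12`: 250 ug/mL

Of the two, compound 2 has the higher number, 250 ug/mL, which makes it the weaker inhibitor. For the measured compounds named here, the only measured step, a 6.6-fold higher number from compound 1 to compound 2 (0.82 log units; beyond the scatter), came with 2,4-difluorophenyl in place of cyclopropyl on an aromatic nitrogen. Compound 3 `CC1(N)CCN(c2c(F)cc3c(=O)c(C(=O)O)cn(-c4ccc(F)cc4F)c3c2C(F)(F)F)C1` keeps that group but has trifluoromethyl in place of methoxy on an aromatic carbon, ortho to a 3-amino-3-methylpyrrolidin-1-yl group: trifluoromethyl in place of methoxy on an aromatic carbon. Going by the values given here, no measured step involves that carbon, so the data give no direct guide to the size or direction of this change. Among the compounds with values here, the step from compound 1 to compound 2 shows only that a single change can move this assay beyond the scatter. The expected change is small, a 1.3-fold lower number from compound 2 to compound 3 (0.10 log units; within the scatter), and its direction is uncertain. For compound 3 the estimated value is 200 ug/mL, with an expected range of 70 ug/mL to 500 ug/mL.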

Compound 3, half-maximal inhibitory concentration: 18 ug/mL
Estimate against measurement, compound 3: 11-fold (1.05 log units) above; measured number below the stated range.
By their numbers in this assay, from the lowest: compound 3; then compound 1; then compound 2.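

In this assay, this aromatic carbon proves to be a sensitive position: a 14-fold lower number from compound 2 to compound 3 (1.14 log units; beyond the scatter), so trifluoromethyl in place of methoxy gives a stronger inhibitor by a margin beyond the scatter. For the compounds shown here, until now, the only measured change was on the aromatic nitrogen, where 2,4-difluorophenyl in place of cyclopropyl went the opposite way, with a 6.6-fold higher number from compound 1 to compound 2 (0.82 log units; beyond the scatter), so single changes at these two places can push the number in either direction. No measurement shown explains why this swap lowers the number.

On these data alone, it remains open whether trifluoromethyl is special here or whether a chloro, methyl or nitrile group on the same carbon would do the same. Also open is whether the swap would lower the number with cyclopropyl on the aromatic nitrogen, as the pair shown carries 2,4-difluorophenyl.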